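A few compounds are considered here, and "the series" means these few. Any claim that something is new, unique, unknown or untested is made for them only; others in the source may bear on it.

Working notes on the series.

Three members have been run in an ADME assay on microsomes from liver (Homo sapiens) for metabolic stability, with a stated time of 10 min; a lower number here means that less of the compound is left, a higher number that more of the compound is left. Compound 1, `COc1nn2cc(-c3cc4ccc(OC)c(OC)c4o3)nc2s1`, gives 20%. Compound 2, `COc1cc(OCc2cccc(COc3ccccc3)c2)c2cc(-c3cn4nc(OC)sc4n3)oc2c1`, gives 86% in this assay. Compound 3, `COc1cc(OCc2ccccc2OCc2ccccc2)c2cc(-c3cn4nc(OC)sc4n3)oc2c1`, gives 94% in this assay. On these three numbers compound 2 stands second highest; its nearest neighbour is compound 3, whose number lies within the scatter of that of compound 2, so no order between the two is claimed, while compound 1 lies far lower, well beyond the scatter. Going by the values given here, no step between two measured compounds differing in one place is recorded, so nothing can be read from single changes so far.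

Compound 4, `COc1cc(OCc2cccc(OCc3ccccc3)c2)c2cc(-c3cn4nc(OC)sc4n3)oc2c1`, has not yet been measured. It differs from compound 2 in one place only: benzyloxy in place of phenoxymethyl on an aromatic carbon, meta to a large group, with the same atoms joined differently. Both compound 2, with 86%, and compound 3, with 94%, keep most of the compound over the run, and compound 4 carries the same kind of arm, so no step beyond the scatter is expected in either direction. The step from compound 2 to compound 4 is estimated as a number 2 percentage points lower from compound 2 to compound 4 (within the scatter). For compound 4 the expected value in this assay is 84%, with a range from 62% to 97%.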

Compound 4, percent of the compound remaining: 85%
Beside the measured number, compound 4's estimate is 1 percentage points below it; the measured number falls inside the stated range.
By their numbers in this assay, from the lowest: compound 1; then compounds 4, 2 and 3 (each within the scatter of the next).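

In this assay the series now has its first step between two compounds differing in one place: a number 1 percentage points lower from compound 2 to compound 4 (within the scatter), with benzyloxy in place of phenoxymethyl on an aromatic carbon, meta to a large group. At this position, then, joining the same atoms differently leaves the percent remaining within the scatter, and the two arms cannot be told apart on this read-out. Nothing available gives a reason for this result.

On these data alone, this is one exchange at one place, and whether it would behave alike elsewhere on that ring stays open. Also open, as far as these compounds go, is whether a longer chain in place of benzyloxy, or an amine or a carboxylic acid on its ring, would shift the number beyond the scatter.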